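The source may report more compounds than this note shows. Statements on the series, on what has been measured and on what is new or still open speak of the compounds shown alone.

Working notes on the series. Among the compounds with values here, in an ADME assay on MT4 cells (Homo sapiens) for cytotoxicity, read by MTT assay (a lower number here means that less compound is tolerated, a higher number that more compound is tolerated), compound 1 `Cc1cc(C)cc(S(=O)(=O)c2c(C(=O)NC(C)C(=O)NCc3ccco3)[nH]c3ccc(Cl)cc23)c1` gives 24200 nM, the only plain number among the three values shown. For compound 2 `Cc1cc(C)cc(S(=O)(=O)c2c(C(=O)NCc3n[nH]c4ccccc34)[nH]c3ccc(Cl)cc23)c1` this assay returns a limit, > 50700 nM. For compound 3 `Cc1cc(C)cc(S(=O)(=O)c2c(C(=O)NC(C)c3ccco3)[nH]c3ccc(Cl)cc23)c1` this assay likewise returns a limit, > 54700 nM. Read as steps, the change of an at least 2.0-fold higher number from compound 1 to compound 2 (0.32 log units; beyond the scatter) and the change of an at least 2.2-fold higher number from compound 1 to compound 3 (0.35 log units; beyond the scatter) both run upward, each beyond the scatter but capped by a limit, so the true size of either is open; the pair of compound 2 and compound 3 cannot be ordered, both sitting at a limit.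

Compound 4 `Cc1cc(C)cc(S(=O)(=O)c2c(C(=O)NC(C)c3cc(F)cc(F)c3)[nH]c3ccc(Cl)cc23)c1` differs from compound 1 by 3,5-difluorophenyl in place of ((furan-2-yl)methyl)carbamoyl on a saturated chain carbon bound to an amide-type nitrogen and a saturated chain carbon. This change sits at the same saturated chain carbon as the step to compound 3, where the same leaving group was replaced and the number rose by an at least 2.2-fold higher number from compound 1 to compound 3 (0.35 log units; beyond the scatter). The step to compound 2 points the same way. The expectation for compound 4 in this assay is therefore an upward step, a 2.1-fold higher number from compound 1 to compound 4 (0.33 log units; beyond the scatter), quite possibly ending again at a limit. Compound 4 is estimated at 52000 nM, within 22000 nM to 120000 nM.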

Compound 4, half-maximal cytotoxic concentration: > 49700 nM
Compound 4 was reported as a limit (the forecaster's own chance of this, stated with the estimate: 60%); the middle value does not contradict the limit.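

In this assay, putting 3,5-difluorophenyl in place of ((furan-2-yl)methyl)carbamoyl on this saturated chain carbon gives an at least 2.0-fold higher number from compound 1 to compound 4 (0.31 log units; beyond the scatter), so the upward move also holds with a six-membered aromatic ring of carbon only and is not tied to furan-2-yl as the entering group. Compound 4 is reported only as a limit: the limit of > 49700 nM in this assay, at which 1 of the 4 values shown sits. The steps from compound 2 and compound 3 to compound 4 cannot be read, so the 3,5-difluorophenyl and furan-2-yl groups cannot be told apart in this assay.

Going by these compounds, the true size of the rise from compound 1 remains open, since all the other values are limits. Also open, on these data alone, is whether an amine or a carboxylic acid at this saturated chain carbon would keep the number clear of compound 1 at 24200 nM.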